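From chloro to trifluoromethyl: a step not yet measured

The compounds below may be only part of what the source reports. "The series", "measured", "known", "first", "only" and "open" are said of these compounds alone.

In a functional assay on K562 cells (Homo sapiens) for antiproliferative activity, read by MTT assay, with a stated time of 48 h (on this read-out lower numbers stand for stronger inhibition and higher numbers for weaker inhibition), compound 1 `COc1ccc(Nc2nc(Nc3cnn(CCCCCCC(=O)NO)c3)ncc2Cl)cc1` gives 620 nM while compound 2 `O=C(CCCCCCn1cc(Nc2ncc(Cl)c(Nc3ccc(F)cc3)n2)cn1)NO` gives 500 nM and compound 3 `O=C(CCCCCCn1cc(Nc2ncc(Cl)c(Nc3ccccc3)n2)cn1)NO` gives 420 nM on the same scale. Compound 2 sits numerically between the other two, but it cannot be told apart from either: the step of a 1.2-fold lower number from compound 1 to compound 2 (0.09 log units; within the scatter) and the step of a 1.2-fold lower number from compound 2 to compound 3 (0.08 log units; within the scatter) both lie within the scatter.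

Compound 4 `O=C(CCCCCCn1cc(Nc2ncc(C(F)(F)F)c(Nc3ccc(F)cc3)n2)cn1)NO` differs from compound 2 in one place only. The change is trifluoromethyl in place of chloro on an aromatic carbon and it puts trifluoromethyl in place of chloro on an aromatic carbon, ortho to a (4-fluorophenyl)amino group.

Among the compounds with values here, no measured pair varies this place. All three measured steps swap methoxy, fluoro or hydrogen elsewhere, and even the widest of them a 1.5-fold lower number from compound 1 to compound 3 (0.17 log units; within the scatter) stays within the scatter. They show a steady series, but they give only indirect guidance on the new change. No step beyond the scatter is therefore expected, though with real uncertainty in either direction. The estimated step is a 1.1-fold higher number from compound 2 to compound 4 (0.04 log units; within the scatter) in this reading. Compound 4 is expected at about 550 nM with an estimated range of 220 nM to 1400 nM in this assay when it is measured.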

Compound 4, half-maximal inhibitory concentration: 480 nM
Estimate against measurement, compound 4: 1.1-fold (0.06 log units) above, and the stated range covers the measured number.
By their numbers in this assay, from the lowest: compounds 3, 4, 2 and 1 (each within the scatter of the next).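

In this assay, within the data shown here, the step at this position reads a 1.0-fold lower number from compound 2 to compound 4 (0.02 log units; within the scatter), the first measured change on this carbon of the shared core, ortho to a (4-fluorophenyl)amino group. The earlier compounds shown here varied only the substituent on the outer aromatic ring, so they could not show that this position accepts trifluoromethyl, with 4 heavy atoms, in place of chloro, with 1 heavy atom, without a change that can be told from the scatter of the read-out. Nothing measured here explains why the two groups cannot be told apart, so this result records what happens at the position and gives no reason for it.

The compounds shown carry only chloro and trifluoromethyl at this place, which leaves open whether a smaller or different group, such as hydrogen, methyl, a nitrile or an amine, would also leave the number within the scatter of compound 2. This single pair also leaves open whether the same swap would read alike with methoxy or hydrogen in place of fluoro on the outer ring, or with a longer chain leading to the hydroxamic acid end.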